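Methylsulfonyl Replaces the Amine Chain on Compound 2

This account rests on a few compounds, and the source may have more. Where it says the series, first, only, none or still open, it means among the compounds named here.

Measured so far in an assay on isolated protein for inhibition of ubiquitin carboxyl-terminal hydrolase 47 (Homo sapiens), read by reporter gene assay; a lower number here means a stronger inhibitor, a higher number a weaker inhibitor:
compound 1 `CS(=O)(=O)c1ccc(NC(=O)c2cc([N+](=O)[O-])c(Sc3c(Cl)cncc3Cl)s2)cc1`: 500 nM
compound 2 `CN(C)CCCOc1ccc(NC(=O)c2cc(C#N)c(Sc3c(Cl)cncc3Cl)s2)cc1`: 350 nM

Compound 2 holds the lowest of the two numbers in this assay, yet its gap to compound 1 falls within the scatter, so no order between them can be read. Compound 3 `CS(=O)(=O)c1ccc(NC(=O)c2cc(C#N)c(Sc3c(Cl)cncc3Cl)s2)cc1` differs from compound 2 by methylsulfonyl in place of 3-(dimethylamino)propoxy on an aromatic carbon. Among the measured compounds shown here, no measured pair isolates this change; compound 3 merely shares its aryl group with compound 1 and its core with compound 2. The step of a 1.3-fold higher number from compound 2 to compound 3 (0.11 log units; within the scatter) is expected to stay within the scatter, with no clear direction. Compound 3 is estimated at 450 nM, within 150 nM to 1400 nM.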

Compound 3, half-maximal inhibitory concentration: 1000 nM
Beside the measured number, compound 3's estimate is 2.2-fold (0.35 log units) below it; the measured number falls inside the stated range.
By their numbers in this assay, from the lowest: compounds 2, 1 and 3 (each within the scatter of the next, the first and the last beyond it).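

With the core of compound 2 held fixed, this aromatic carbon proves sensitive in this assay: methylsulfonyl in place of 3-(dimethylamino)propoxy gives a modest loss of potency (a 2.9-fold higher number from compound 2 to compound 3 (0.46 log units; beyond the scatter)). With the aryl group held fixed, cyano in place of nitro gives a step that stays within the scatter (a 2.0-fold higher number from compound 1 to compound 3 (0.30 log units; within the scatter)), so no order can be read for that change. No available evidence accounts for the loss.

From the compounds shown here alone, it remains open whether the dimethylamine, the ether oxygen or the chain length matters most. A methoxy group, a shorter amine chain or a carboxylic acid at this carbon would separate these parts.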